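The source may hold more compounds than are shown below. What is called first, only, known or untested is meant among the compounds shown, and "the series" means these compounds.

Measured compounds:
- compound 1 `Nc1cccc(-c2cn3nc(Cc4ccccc4)sc3n2)c1` gives 37000 nM
- compound 2 `Nc1cccc(-c2cn3nc(Cc4ccc(Cl)cc4)sc3n2)c1` gives 42000 nM
- compound 3 `C=C(Br)C(=O)Nc1cccc(-c2cn3c(-c4ccccc4)csc3n2)c1` gives 2800 nM

All three values come from a functional assay on CCRF-CEM cells (Homo sapiens) for inhibition, read by cell counting, with a stated time of 3 days; on this read-out higher numbers stand for weaker inhibition and lower numbers for stronger inhibition. Compound 1 and compound 2 share a core and differ only by chloro in place of hydrogen on an aromatic carbon; this step, a 1.1-fold higher number from compound 1 to compound 2 (0.06 log units; within the scatter), is within the scatter. Compound 3 carries a different core; the difference between the two cores is not broken down here. In this assay compound 3 has the lowest number of the three, and its gap to compound 1 and to compound 2 is beyond the scatter.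

Compound 4 `C=C(Br)C(=O)Nc1cccc(-c2cn3c(-c4ccc(Cl)cc4)csc3n2)c1` is not yet measured. It differs from compound 3 by chloro in place of hydrogen on an aromatic carbon, the same change that leads from compound 1 to compound 2. Because a 1.1-fold higher number from compound 1 to compound 2 (0.06 log units; within the scatter) stayed within the scatter, the step from compound 3 to compound 4 is expected to be small as well, a 1.1-fold higher number from compound 3 to compound 4 (0.03 log units; within the scatter), though it rests on a single measured pair on another core. The value of compound 4 in this assay is therefore estimated at 3000 nM, with a range from 1200 nM to 7500 nM.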

Compound 4, half-maximal inhibitory concentration: 2200 nM
The estimate for compound 4 lay 1.4-fold (0.13 log units) above the measured number; measured number inside the range.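

In this assay the new step is a 1.3-fold lower number from compound 3 to compound 4 (0.10 log units; within the scatter) and stays small, as the earlier step on the other core did. Set side by side, the two steps do not differ: the same change on two cores in this assay, a 1.1-fold higher number (0.06 log units; within the scatter) from compound 1 to compound 2 and a 1.3-fold lower number (0.10 log units; within the scatter) from compound 3 to compound 4, 1.4-fold (0.16 log units) apart, within the scatter of two such steps. Going by these compounds alone, this shows that chloro in place of hydrogen on the aromatic carbon, read here as phenyl to 4-chlorophenyl, carried over between these two cores as a small change, but it rests on only two pairs and does not show that the same would hold on any further core.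

Still open, from the compounds shown here alone, is whether other groups at this place, such as methoxy, a carboxylic acid or a dimethylamino group, would also give a small step on both cores. Also open is how much of the gap between compound 1 and compound 3 belongs to the bromine-bearing amide and how much to the core; no pair shown separates the two.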